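Swapping the Allyl Arm of Compound 2 for a Benzyl

A few compounds are considered here, and "the series" means these few. Any claim that something is new, unique, unknown or untested is made for them only; others in the source may bear on it.

Compound 1 `COc1ccc(-c2ccc3c(c2)C(=O)C(=O)N3)cc1`: 6920 nM
Compound 2 `C=CCN1C(=O)C(=O)c2cc(-c3ccc(OC)cc3)ccc21`: 390 nM
Compound 3 `COc1ccc(-c2ccc3c(c2)C(=O)C(=O)N3Cc2ccc(F)cc2)cc1`: 560 nM

In a functional assay on K562 cells (Homo sapiens) for antiproliferative activity, read by MTT assay, with a stated time of 48 h (a higher number here means a weaker inhibitor, a lower number a stronger inhibitor), compound 2 gives 390 nM, the lowest of the three numbers. Compound 3 stands close to it, a 1.4-fold higher number from compound 2 to compound 3 (0.16 log units; within the scatter), so the two cannot be told apart. Compound 1, which carries only hydrogen on the amide-type nitrogen in the ring, is far off: an 18-fold lower number from compound 1 to compound 2 (1.25 log units; beyond the scatter) and a 12-fold lower number from compound 1 to compound 3 (1.09 log units; beyond the scatter), both large steps of similar size, showing that putting any of these two groups on that nitrogen matters a great deal, whereas which group it is mattered little between compound 2 and compound 3.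

Compound 4 `COc1ccc(-c2ccc3c(c2)C(=O)C(=O)N3Cc2cc(C)cc(C)c2)cc1` has not yet been measured. It differs from compound 2 in one place: 3,5-dimethylphenyl in place of vinyl on a saturated chain carbon bound to an amide-type nitrogen in a ring. Going by the values given here, the one measured step that bears on this is a 1.4-fold higher number from compound 2 to compound 3 (0.16 log units; within the scatter), where an aromatic ring likewise entered in place of vinyl at the same place and the number barely moved. Nothing measured here speaks to the two methyl groups. The step of a 1.4-fold higher number from compound 2 to compound 4 (0.15 log units; within the scatter) is therefore expected to stay within the scatter, with no clear direction. Compound 4 is expected to give about 550 nM, within a range from 200 nM to 1500 nM.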

Compound 4, half-maximal inhibitory concentration: 140 nM
Estimate against measurement, compound 4: 3.9-fold (0.59 log units) above; the measured number lies below the stated range.
By their numbers in this assay, from the lowest: compound 4; then compounds 2 and 3 (each within the scatter of the next); then compound 1.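

In this assay, the aromatic ring on the saturated chain carbon bound to the ring nitrogen turns out not to be interchangeable: there is a 4.0-fold lower number from compound 3 to compound 4 (0.60 log units; beyond the scatter) when 3,5-dimethylphenyl replaces 4-fluorophenyl, so what the ring carries can shift the number even though only a ring swap separates the two. Nor does an aromatic ring at this place always beat vinyl: there is a 2.8-fold lower number from compound 2 to compound 4 (0.44 log units; beyond the scatter) with 3,5-dimethylphenyl, while compound 3 with its 4-fluorophenyl goes against any such rule by staying within the scatter of compound 2. Substitution on the nitrogen also now reaches further than before, with a 49-fold lower number from compound 1 to compound 4 (1.69 log units; beyond the scatter) for 3,5-dimethylbenzyl in place of hydrogen, a wider gap than either earlier group opened, though nothing shown here gives a reason for these differences.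

The compounds shown leave open whether both methyl groups are needed, since a plain benzyl or a benzyl with a single methyl would separate their shares from that of the ring. They also leave open whether chlorine atoms or methoxy groups in place of those two methyl groups would give a similar number.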